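Pendant aryl variation and lipophilicity in one series

The source may hold more compounds than are shown below. What is called first, only, known or untested is meant among the compounds shown, and "the series" means these compounds.

Measured so far in a physicochemical assay for lipophilicity, read by HPLC, at pH 7.4; on this read-out lower numbers stand for lower lipophilicity and higher numbers for higher lipophilicity:
compound 1 `CNc1nc(NCCCN(C)C)c2sc(-c3ccc(N)cc3)cc2n1`: 2.3
compound 2 `CNc1nc(NCCCN(C)C)c2sc(-c3cccc(C#N)c3)cc2n1`: 2.9
compound 3 `CNc1nc(NCCCN(C)C)c2sc(-c3ccc(C(F)(F)F)cc3)cc2n1`: 4.1

Compound 2 sits second highest of the three numbers: compound 1 lies a number 0.60 log units higher from compound 1 to compound 2 (beyond the scatter) below it, and compound 3 at 4.1 lies well above it. Compound 4 `CNc1nc(NCCCN(C)C)c2sc(-c3ccc(OC)nc3)cc2n1` is not yet measured in this assay. It differs from compound 2 by 6-methoxypyridin-3-yl in place of 3-cyanophenyl on an aromatic carbon, on an aromatic carbon of the five-membered aromatic ring with one sulfur, next to the ring sulfur. Among the measured compounds shown here, no measured step covers this exact swap; the two recorded steps, a number 0.60 log units higher from compound 1 to compound 2 (beyond the scatter) and a number 1.80 log units higher from compound 1 to compound 3 (beyond the scatter), both replace an amino group on the pendant ring and so bear only loosely. A small step, possibly downward but likely within the scatter, is expected: compound 4 is estimated at 2.7, range 2.2 to 3.2. The expected step of a number 0.20 log units lower from compound 2 to compound 4 (within the scatter) is therefore modest.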

Compound 4, distribution coefficient: 2.8
Beside the measured number, compound 4's estimate is 0.10 log units below it; measured number inside the range.
By their numbers in this assay, from the lowest: compound 1; then compounds 4 and 2 (each within the scatter of the next); then compound 3.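

In this assay, exchanging a carbon-only pendant ring bearing a nitrile for 6-methoxypyridin-3-yl on this aromatic carbon gives a number 0.10 log units lower from compound 2 to compound 4 (within the scatter) and so separates neither compound. The other step, a number 0.50 log units higher from compound 1 to compound 4 (beyond the scatter), means that all three replacements of 4-aminophenyl shown now read beyond the scatter from compound 1. No supporting data accompany these results to account for either step.

As far as these compounds go, how plain phenyl, or a pyridine ring without the methoxy group, would read on this carbon remains open. The ring nitrogen and methoxy group of compound 4 therefore cannot be weighed separately.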